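Swapping the Amide Substituent: An Expectation for Compound 4

The source may hold more compounds than are shown below. What is called first, only, known or untested is meant among the compounds shown, and "the series" means these compounds.

Of the compounds shown here, three sharing one core have been tested in an ADME assay on HUVEC cells (Homo sapiens) for cytotoxicity, read by MTT assay, with a stated time of 72 h; on this read-out lower numbers stand for stronger inhibition and higher numbers for weaker inhibition. Compound 1 `Cc1ccccc1NC(=O)CCC(=O)OCCCCCCSc1ccc([N+](=O)[O-])c2nonc12` gives 1410 nM, the lowest of the three numbers. Compound 2 `CN(C)CCCNC(=O)CCC(=O)OCCCCCCSc1ccc([N+](=O)[O-])c2nonc12` gives 1600 nM and compound 3 `CN(C)CCNC(=O)CCC(=O)OCCCCCCSc1ccc([N+](=O)[O-])c2nonc12` gives 2160 nM; the steps of a 1.1-fold higher number from compound 1 to compound 2 (0.05 log units; within the scatter) and a 1.5-fold higher number from compound 1 to compound 3 (0.19 log units; within the scatter) both lie within the scatter, as does a 1.4-fold higher number from compound 2 to compound 3 (0.13 log units; within the scatter). Compound 4 `O=C(CCC(=O)OCCCCCCSc1ccc([N+](=O)[O-])c2nonc12)NCCN1CCCC1` carries 2-(pyrrolidin-1-yl)ethyl in place of 2-methylphenyl on an amide-type nitrogen. The earlier replacements of 2-methylphenyl by 3-(dimethylamino)propyl and 2-(dimethylamino)ethyl, a 1.1-fold higher number from compound 1 to compound 2 (0.05 log units; within the scatter) and a 1.5-fold higher number from compound 1 to compound 3 (0.19 log units; within the scatter), bear on this change and stayed within the scatter. Compound 4 is therefore expected to show no step beyond the scatter, a 1.3-fold higher number from compound 1 to compound 4 (0.13 log units; within the scatter), with an estimated 1900 nM in this assay and a range from 900 nM to 4000 nM.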

Compound 4, half-maximal inhibitory concentration: 6070 nM
Estimate against measurement, compound 4: 3.2-fold (0.50 log units) below; the whole stated range lies below it.
By their numbers in this assay, from the lowest: compounds 1, 2 and 3 (each within the scatter of the next); then compound 4.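

In this assay, within the data shown here, the substituent on this amide-type nitrogen does make a difference: 2-(pyrrolidin-1-yl)ethyl gives the first steps beyond the scatter (a 4.3-fold higher number from compound 1 to compound 4 (0.63 log units; beyond the scatter)) and (a 3.8-fold higher number from compound 2 to compound 4 (0.58 log units; beyond the scatter)). The change is also visible where only pyrrolidin-1-yl replaces dimethylamino on the ethyl chain (a 2.8-fold higher number from compound 3 to compound 4 (0.45 log units; beyond the scatter)), whereas 3-(dimethylamino)propyl and 2-(dimethylamino)ethyl had stayed within the scatter of 2-methylphenyl. Nothing at hand explains this difference. Going by these compounds, whether a piperidin-1-yl or morpholin-4-yl group on the same ethyl chain would stay with compound 3 or move with compound 4 remains open.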